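A Piperidine Amide and Its Expected Clearance

This account rests on a few compounds, and the source may have more. Where it says the series, first, only, none or still open, it means among the compounds named here.

Measured so far:
compound 1, `CCCN(CC1CCOC1)C(=O)c1cc(OC)c2oc(NCc3cccc(Cl)c3)nc2c1`: 65 mL/min/kg
compound 2, `COc1cc(C(=O)N2CC[C@@H](O)C(C)(C)C2)cc2nc(NCc3cccc(Cl)c3)oc12`: 51.7 mL/min/kg

Both compounds were run in an ADME assay on cells (Hepatocyte, Rattus norvegicus, strain Wistar) for pharmacokinetics, read by LC-MS, with a stated time of 90 min, tested at 1 uM; on this read-out lower numbers stand for slow clearance and higher numbers for fast clearance. Among the compounds with values here, compound 1 stands highest of the two numbers, and the only other number, that of compound 2, sits within the usual scatter of it, so the two cannot be told apart. Compound 3, `COc1cc(C(=O)N2CC[C@H](O)[C@@H](C)C2)cc2nc(NCc3cccc(Cl)c3)oc12`, has not yet been measured. It differs from compound 1 in one place: 4-hydroxy-3-methylpiperidin-1-yl in place of ((oxolan-3-yl)methyl)(propyl)amino on a carbonyl carbon. Within the data shown here, the one measured step that bears on this change is the step in which a closely related hydroxy-bearing piperidine replaced the same ((oxolan-3-yl)methyl)(propyl)amino group on the carbonyl carbon, giving a 1.3-fold lower number from compound 1 to compound 2 (0.10 log units; within the scatter), a shift within the scatter. Since the 4-hydroxy-3-methylpiperidin-1-yl group of compound 3 is a near relative of that piperidine, no step beyond the scatter is expected in this assay, in either direction. The step from compound 1 to compound 3 is therefore expected to be a 1.3-fold lower number from compound 1 to compound 3 (0.10 log units; within the scatter). Compound 3 is estimated at 52 mL/min/kg, with a range from 30 mL/min/kg to 90 mL/min/kg.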

Compound 3, clearance: 36.7 mL/min/kg
For compound 3 the middle estimate is 1.4-fold (0.15 log units) above the measured one; the range from low to high includes it.
By their numbers in this assay, from the lowest: compounds 3, 2 and 1 (each within the scatter of the next).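

In this assay a second hydroxy-bearing piperidine on the carbonyl carbon also stays within the scatter of the ((oxolan-3-yl)methyl)(propyl)amino amide (a 1.8-fold lower number from compound 1 to compound 3 (0.25 log units; within the scatter)). The earlier compounds shown here offered no comparison between two piperidines at this place, and the exchange of 4-hydroxy-3,3-dimethylpiperidin-1-yl for 4-hydroxy-3-methylpiperidin-1-yl now provides one, which also stays within the scatter (a 1.4-fold lower number from compound 2 to compound 3 (0.15 log units; within the scatter)), so this read-out cannot tell the three groups on the carbonyl carbon apart. Nothing available gives a reason for where these three numbers fall.

Both piperidines shown carry the hydroxy group, so its own contribution remains open, and a piperidine without it, or with an amine or a carboxylic acid in its place, would be needed to test whether a step beyond the scatter can arise at this place. Also open, on these data alone, is how the other stereoisomers of the 4-hydroxy-3-methylpiperidin-1-yl group would read, as only one arrangement of its two defined stereocentres appears here.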